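Adding a Methoxy Group to the Amide Aryl Ring

A few compounds are considered here, and "the series" means these few. Any claim that something is new, unique, unknown or untested is made for them only; others in the source may bear on it.

In a functional assay on SK-BR-3 cells (Homo sapiens) for antiproliferative activity, read by MTT assay, with a stated time of 48 h (on this read-out higher numbers stand for weaker inhibition and lower numbers for stronger inhibition), compound 1 `CCCCCCOc1cc(NC(=O)c2ccc(OC)cc2)ccc1N(C)S(C)(=O)=O` gives 20000 nM; compound 2 `CCCCCCOc1cc(NC(=O)c2ccc(OC)c(OC)c2)ccc1N(C)S(C)(=O)=O` gives 100000 nM; compound 3 `COc1ccc(C(=O)Nc2ccc(N(C)S(=O)(=O)C(F)(F)F)c(OCc3cc(C)ccc3C)c2)cc1` gives 5320 nM.

The change from compound 1 to compound 2 is methoxy in place of hydrogen on an aromatic carbon and produced a 5.0-fold higher number from compound 1 to compound 2 (0.70 log units; beyond the scatter). Compound 4 `COc1ccc(C(=O)Nc2ccc(N(C)S(=O)(=O)C(F)(F)F)c(OCc3cc(C)ccc3C)c2)cc1OC` carries the same change made on compound 3, (methoxy in place of hydrogen on an aromatic carbon), and the place is described in the same words for both pairs, so this is the same change. How the core of compound 3 differs from the core of compound 1 is not broken down here; their values in this assay show compound 3 giving the lower number. Compound 4 is expected to move by a 4.5-fold higher number from compound 3 to compound 4 (0.65 log units; beyond the scatter), a step of about the size seen before, because the same change gave a 5.0-fold higher number from compound 1 to compound 2 (0.70 log units; beyond the scatter) in this assay. Compound 4 is therefore estimated at 24000 nM, expected to lie between 8000 nM and 70000 nM.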

Compound 4, half-maximal inhibitory concentration: 39300 nM
Compound 4: middle estimate off by 1.6-fold (0.21 log units), on the low side; low and high end bracket the measured number.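

In this assay the methoxy change gave a 7.4-fold higher number from compound 3 to compound 4 (0.87 log units; beyond the scatter) on the core of compound 3, so the number rose on this core as it had on the core of compound 1. Set beside the earlier step, the change carried over from one core to the other in direction and in size: the same change on two cores in this assay, a 5.0-fold higher number (0.70 log units; beyond the scatter) from compound 1 to compound 2 and a 7.4-fold higher number (0.87 log units; beyond the scatter) from compound 3 to compound 4, 1.5-fold (0.17 log units) apart, within the scatter of two such steps. This rests on just two pairs, so it does not show that the step would hold on any further core, and it says nothing about why the number rises.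

The compounds shown leave open what another group entering at the same place, such as a hydroxyl, an amine or a chlorine atom, would do on either core. They also leave open whether the step holds in other cell lines.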